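The source may hold more compounds than are shown below. What is called first, only, known or untested is meant among the compounds shown, and "the series" means these compounds.

Compound 1 `COc1ccccc1N1CCN(CCCCCOc2c(Br)cc(Br)cc2Oc2ccc(Br)cc2Br)CC1` and compound 2 `C#CCOc1c(Br)cc(Br)cc1Oc1ccc(Br)cc1Br` share the same core. In a functional assay on HL-60 cells (Homo sapiens) for cytotoxicity, read by MTT assay, with a stated time of 24 h (a higher number here means a weaker inhibitor, a lower number a stronger inhibitor), compound 1 gives 32.2 ug/mL. In this assay compound 2 gives 29.7 ug/mL, the lower of the two numbers, though this lies within the scatter of compound 1. Compound 3 `OCCCOc1c(Br)cc(Br)cc1Oc1ccc(Br)cc1Br` has not been measured; it differs from compound 2 in one place: 2-hydroxyethyl in place of ethynyl on a saturated chain carbon bound to an oxygen on an aromatic ring. Among the compounds with values here, no measured pair shows such a change, so nothing beyond the scatter is expected, and the step from compound 2 to compound 3 is estimated as a 1.1-fold higher number from compound 2 to compound 3 (0.03 log units; within the scatter) in this assay. Compound 3 is expected to give about 32 ug/mL, between 15 ug/mL and 65 ug/mL.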

Compound 3, half-maximal inhibitory concentration: 29.9 ug/mL
The estimate for compound 3 lay 1.1-fold (0.03 log units) above the measured number; low and high end bracket the measured number.
By their numbers in this assay, from the lowest: compounds 2, 3 and 1 (each within the scatter of the next).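

In this assay, 2-hydroxyethyl in place of ethynyl, on a saturated chain carbon bound to an oxygen on an aromatic ring, gives a 1.0-fold higher number from compound 2 to compound 3 (0.00 log units; within the scatter). This is the only one-place change shown, and it means that a group with a hydrogen-bond donor and acceptor can replace one with a triple bond at this position without a shift beyond the scatter. No measurement at hand bears on this result.

From the compounds shown here alone, whether a carboxylic acid or an amide at the end of this chain would also leave the number within the scatter remains open.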